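The Same Aryl Exchange on a Second Core

The source may hold more compounds than are shown below. What is called first, only, known or untested is meant among the compounds shown, and "the series" means these compounds.

Of the compounds shown here, three have been measured in a functional assay on MCF7 cells (Homo sapiens) for antiproliferative activity, read by sulforhodamine B assay, with a stated time of 48 h; on this read-out higher numbers stand for weaker inhibition and lower numbers for stronger inhibition. Compound 1 `COc1cccc(/C=C/C(=O)C(=Cc2ccc(O)c(F)c2)C(=O)/C=C/c2cccc(OC)c2OC)c1OC` gives 300 nM in this assay. Compound 2 `COc1cc(C=C(C(=O)/C=C/c2cccc(OC)c2OC)C(=O)/C=C/c2cccc(OC)c2OC)cc(Br)c1O` gives 360 nM in this assay. Compound 3 `COc1cc(OC)c(/C=C/C(=O)C(=Cc2ccc(O)c(F)c2)C(=O)/C=C/c2c(OC)cc(OC)cc2OC)c(OC)c1` gives 3180 nM in this assay and so stands highest of the three: its nearest neighbour is compound 2, the gap to compound 1 is wider still, and both gaps lie beyond the scatter. Compound 4 `COc1cc(OC)c(/C=C/C(=O)C(=Cc2cc(Br)c(O)c(OC)c2)C(=O)/C=C/c2c(OC)cc(OC)cc2OC)c(OC)c1` has not yet been measured.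

Compound 2 differs from compound 1 in one place: 3-bromo-4-hydroxy-5-methoxyphenyl in place of 3-fluoro-4-hydroxyphenyl on a double-bonded chain carbon bound to a double-bonded chain carbon. On this core the exchange brought a 1.2-fold higher number from compound 1 to compound 2 (0.08 log units; within the scatter), so the values of compound 1 and compound 2 cannot be ordered. The difference between the core of compound 1 and the core of compound 3 is not broken down here. Compound 4 differs from compound 3 in the same way: 3-bromo-4-hydroxy-5-methoxyphenyl in place of 3-fluoro-4-hydroxyphenyl on a double-bonded chain carbon bound to a double-bonded chain carbon. The place of the exchange is the same in both pairs, so it is the same change carried onto a second core.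

Because the first core answered with only a 1.2-fold higher number from compound 1 to compound 2 (0.08 log units; within the scatter), the step from compound 3 to compound 4 is expected to be small as well, estimated as a 1.1-fold higher number from compound 3 to compound 4 (0.05 log units; within the scatter) in this assay. Compound 4 is therefore expected to give about 3600 nM in this assay. The expected range for compound 4 runs from 1500 nM to 9000 nM, wide because a 1.2-fold higher number from compound 1 to compound 2 (0.08 log units; within the scatter) is the only earlier measure of how this exchange behaves.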

Compound 4, half-maximal inhibitory concentration: 1460 nM
Beside the measured number, compound 4's estimate is 2.5-fold (0.39 log units) above it; measured number outside the range, below it.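

Going by these compounds alone, on the second core, in this assay, putting 3-bromo-4-hydroxy-5-methoxyphenyl in place of 3-fluoro-4-hydroxyphenyl brought a 2.2-fold lower number from compound 3 to compound 4 (0.34 log units; beyond the scatter), a modest step that can be read, whereas the same exchange on the first core left two values that cannot be ordered. Even so, the two steps cannot be told apart, so these pairs give no firm sign that the core alters what the exchange does: the same change on two cores in this assay, a 1.2-fold higher number (0.08 log units; within the scatter) from compound 1 to compound 2 and a 2.2-fold lower number (0.34 log units; beyond the scatter) from compound 3 to compound 4, 2.6-fold (0.42 log units) apart, within the scatter of two such steps. This does not show that the change carries over unaltered, since two pairs in a single assay are too few to settle that, and the exchange alters the fluorine, the bromine and the methoxy group at once, so it cannot say which of them matters on either core.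

The compounds shown leave open whether the exchange would behave the same way with a chlorine or a nitrile in place of the bromine, or with an amine or a carboxylic acid in place of the hydroxy group. They also leave open how the step would run on any core beyond these two, and which part of the difference between the two cores sets their overall level in this assay.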